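Ring size and acid placement on the aryl amine

The compounds below may be only part of what the source reports. "The series", "measured", "known", "first", "only" and "open" are said of these compounds alone.

Measured in a functional assay on cells for agonist activity at Free fatty acid receptor 1 (Homo sapiens), read by FLIPR and calcium flux, with a stated time of 100 s; a higher number here means that more compound is needed for the effect, a lower number that less compound is needed:
compound 1 `O=C(O)C1CCN(c2ccc(OCc3ccc(Cl)cc3Cl)cc2)C1`, 2100 nM
compound 2 `O=C(O)CC1CCN(c2ccc(OCc3ccc(Cl)cc3Cl)cc2)C1`, > 33000 nM
compound 3 `O=C(O)C[C@@H]1CCCN1c1ccc(OCc2ccc(Cl)cc2Cl)cc1`, 340 nM

Compound 1 stands highest of the two numbers available in this assay. Compound 3 gives 340 nM, whereas compound 1 gives 2100 nM. For compound 2 the assay reports only a limit, > 33000 nM, the same limit as the limit of > 33000 nM in this assay, at which 1 of the 3 values shown sits.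

Compound 4 `O=C(O)C[C@H]1CCN1c1ccc(OCc2ccc(Cl)cc2Cl)cc1` differs from compound 1 by 2-(carboxymethyl)azetidin-1-yl in place of 3-carboxypyrrolidin-1-yl on an aromatic carbon. Among the compounds with values here, one measured step bears on this: an at least 15-fold higher number from compound 1 to compound 2 (1.19 log units; beyond the scatter), where carboxymethyl in place of carboxy on a saturated ring carbon of the pyrrolidine carried the number out to the limit. Compound 3, however, shows that a carboxymethyl group on the ring carbon next to the nitrogen can be paired with a number well below that of compound 1. Within the data shown here, the change to compound 4 places the carboxymethyl in the same relation to the ring nitrogen as in compound 3, but on a four-membered ring, for which no measured step exists.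

On balance a moderate decrease is expected, a 2.3-fold lower number from compound 1 to compound 4 (0.37 log units; beyond the scatter), with wide uncertainty. Compound 4 is estimated at 900 nM, within 200 nM to 5000 nM.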

Compound 4, half-maximal effective concentration: 13000 nM
Estimate against measurement, compound 4: 14-fold (1.16 log units) below; the whole stated range lies below it.
By their numbers in this assay, from the lowest: compound 3; then compound 1; then compound 4. At a limit, above all of these: compound 2.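

Measured in this assay the exchange of 3-carboxypyrrolidin-1-yl for 2-(carboxymethyl)azetidin-1-yl, with the same atoms joined differently, gives a 6.2-fold higher number from compound 1 to compound 4 (0.79 log units; beyond the scatter). A carboxymethyl group on a saturated ring therefore does not by itself bring a low number: compound 3 gives 340 nM and compound 4 gives 13000 nM, so the four-membered ring does not keep the value of compound 3. Nothing measured here accounts for this step.

Open, from the compounds shown here alone, is how a piperidine carrying a carboxylic acid or a carboxymethyl group would compare at this aromatic carbon. Also open, going by these compounds, is whether a carboxyethyl chain on the four-membered ring, or the opposite configuration at its stereocentre, would change the number in this assay.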